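This account rests on a few compounds, and the source may have more. Where it says the series, first, only, none or still open, it means among the compounds named here.

Of the compounds shown here, three from one series have been tested in an ADME assay on Huh-7 cells (Homo sapiens) for cytotoxicity; a lower number here means a stronger inhibitor of growth, a higher number a weaker inhibitor of growth. Compound 1 `COc1cc2c(=O)c(C(=O)c3ccc(C)cc3)cn(Cc3ccc(Cl)cc3)c2cc1OC` gives 15500 nM. Compound 2 `COc1cc2c(=O)c(C(=O)c3ccc(C)cc3)cn(CC3CC3)c2cc1OC` was recorded as "not active" (no number reported), with no number reported. Compound 3 `COc1cc2c(=O)c(C(=O)c3ccc(C)cc3)cn(Cc3ccccc3)c2cc1OC` was likewise recorded as "not active" (no number reported), without a number, so it stands among the entries of this set that have no value at all, while compound 1 alone carries one.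

Compound 4 `COc1cc2c(=O)c(C(=O)c3ccc(C)cc3)cn(CCCc3ccccc3)c2cc1OC` differs from compound 3 in one place: phenethyl in place of phenyl on a saturated chain carbon bound to an aromatic nitrogen. Going by the values given here, no measured step between two compounds of this kind is available in this assay, so the size of the change, if any, cannot be read from data; the expectation is for no clear gain in growth inhibition, with a good chance that again only a limit is reported. Compound 4 is estimated at 30000 nM, within a range of 10000 nM to 100000 nM.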

Compound 4, concentration for 50% growth inhibition: "not active" (no number reported)
No number was reported for compound 4; there is nothing to compare the estimate with.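

Compound 3 and compound 4 were both recorded as not active, with no number, so no step can be read between them. The compounds shown leave open whether the chain length affects growth inhibition at all. No other data here bear on this result.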